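This account rests on a few compounds, and the source may have more. Where it says the series, first, only, none or still open, it means among the compounds named here.

Measured so far in a functional assay on HCT-116 cells (Homo sapiens) for antiproliferative activity, read by MTT assay, with a stated time of 48 h (a lower number here means a stronger inhibitor, a higher number a weaker inhibitor), are three compounds.

compound 1 `COc1ccc(-c2c(Nc3ccc(NC(C)=O)cc3)c3ccccc3oc2=O)cc1` gives "not determined" (no result reported)
compound 2 `COc1ccc(-c2c(Nc3ccc(F)cc3)c3ccc(O)cc3oc2=O)cc1` gives 66100 nM
compound 3 `COc1ccc(Nc2c(C(=O)C(F)(F)F)c(=O)oc3ccc(OC)cc23)cc1` gives "not determined" (no result reported)

Going by the values given here, compound 3 has no single number in this assay and compound 1 likewise has none, so compound 3 cannot be ranked against compound 2, the only compound with a figure. Compound 4 `COc1ccc2oc(=O)c(C(=O)C(F)(F)F)c(Nc3ccc(C)c(O)c3)c2c1` has the same atoms as compound 3, joined differently: it carries 3-hydroxy-4-methylphenyl in place of 4-methoxyphenyl on a nitrogen on an aromatic ring. Among the compounds with values here, no measured step exists to scale this change, and without a number for compound 3 the data give no size or direction for it, so no step beyond the usual scatter is assumed. The expectation leans instead on compound 2 at 66100 nM as the sole anchor, with compound 4 expected to be somewhat stronger than that figure, though with wide uncertainty. The estimated value for compound 4 is 20000 nM within an expected range of 4000 nM to 80000 nM in this measurement.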

Compound 4, half-maximal inhibitory concentration: 4620 nM
Compound 4: middle estimate off by 4.3-fold (0.64 log units), on the high side; measured number inside the range.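

Going by these compounds alone, compound 3 has no single number, so no step to compound 4 can be read from this pair. The compounds shown leave open what replacing 4-methoxyphenyl with 3-hydroxy-4-methylphenyl does to activity. No supporting evidence bears on this result.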